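The source may report more compounds than this note shows. Statements on the series, on what has been measured and on what is new or still open speak of the compounds shown alone.

Three compounds share one core and differ in the group on a single aromatic carbon. In an ADME assay on MOLT-3 cells (Homo sapiens) for cytotoxicity, with a stated time of 7 days (a lower number here means that less compound is tolerated, a higher number that more compound is tolerated), compound 1 `CC(C)CSc1nc(N)nc2c1ncn2/C=C1/CC1(CO)CO` has the entry "not determined" (no result reported), so it offers no guidance. Compound 2 `CCOc1nc(N)nc2c1ncn2/C=C1/CC1(CO)CO` reads > 20000 nM, which is a limit of the assay and not a number. Compound 3 `CCCSc1nc(N)nc2c1ncn2/C=C1/CC1(CO)CO` reads > 20000 nM, which is likewise a limit. Within the data shown here, compound 3 therefore has no exact position on the scale, and no measured compound here provides a number to compare it with.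

The next compound, compound 4 `Nc1nc(NC2CCCC2)c2ncn(/C=C3/CC3(CO)CO)c2n1`, has cyclopentylamino in place of propylsulfanyl on that aromatic carbon: cyclopentylamino in place of propylsulfanyl on an aromatic carbon. Among the measured compounds shown here, the one measured step that bears on this change is at the same carbon, a step that the two limits leave unreadable from compound 2 to compound 3. It gives no size or direction to carry over. The other guide is the limit of > 20000 nM in this assay, at which 2 of the 3 values shown sit. Neither of these shows how a ring-bearing amino group would behave, so the expectation is cautious: no step beyond the scatter, with a good chance that compound 4 also reaches the limit. The estimated change is a step that the limit leaves unreadable from compound 3 to compound 4. For compound 4, the expected value is 25000 nM, with an estimated range from 8000 nM to 60000 nM.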

Compound 4, half-maximal cytotoxic concentration: > 20000 nM
Compound 4: only a limit was reported (the forecaster's own chance of this, stated with the estimate: 70%); the middle value is on the limit's open side.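

In this assay compound 4 gives > 20000 nM, which is a limit of the assay and not a number. Among these compounds, compound 2 and compound 3 also stand at limits, so no step among compound 2, compound 3 and compound 4 can be read. The compounds shown leave open how far each one lies past the limit, and whether ethoxy, propylsulfanyl and cyclopentylamino differ at all.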